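The source may report more compounds than this note shows. Statements on the series, on what has been measured and on what is new or still open speak of the compounds shown alone.

Compound 1 `CN1CCN(CCCOc2cccc3nc(Nc4ccc(Cl)c(F)c4)ccc23)CC1` and compound 2 `CN1CCN(CCCOc2cccc3nc(Nc4ccc(F)c(F)c4)ccc23)CC1` share one core and differ only in the halogens on the outer ring. In a functional assay on cells (Panel colon (Carcinoma cell lines), Homo sapiens) for inhibition, read by sulforhodamine B assay, with a stated time of 48 h (a higher number here means a weaker inhibitor of growth, a lower number a stronger inhibitor of growth), compound 1 gives 1620 nM, and compound 2 gives 2110 nM. The step of a 1.3-fold higher number from compound 1 to compound 2 (0.11 log units; within the scatter) is small, so compound 2 stands highest of the two numbers but within the scatter of compound 1.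

Compound 3 `CN1CCN(CCCOc2cccc3nc(Nc4cc(Cl)cc(Cl)c4)ccc23)CC1` differs from compound 2 by 3,5-dichlorophenyl in place of 3,4-difluorophenyl on a nitrogen on an aromatic ring. For the measured compounds named here, the only measured step that bears on this, from compound 1 to compound 2, exchanged one halogen for another on the same ring and stayed within the scatter. Going by the values given here, no measured compound carries a 3,5-dichlorophenyl group, so the effect of that arrangement is unknown. The expectation is therefore a step of a 1.2-fold lower number from compound 2 to compound 3 (0.07 log units; within the scatter) in this assay, with no direction beyond the scatter. Compound 3 is estimated at 1800 nM, in the range 700 nM to 4500 nM.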

Compound 3, concentration for 50% growth inhibition: 1680 nM
Beside the measured number, compound 3's estimate is 1.1-fold (0.03 log units) above it; measured number inside the range.
By their numbers in this assay, from the lowest: compounds 1, 3 and 2 (each within the scatter of the next).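

In this assay, 3,5-dichlorophenyl in place of 3,4-difluorophenyl on the nitrogen gives a 1.3-fold lower number from compound 2 to compound 3 (0.10 log units; within the scatter), and the same group in place of 4-chloro-3-fluorophenyl gives a 1.0-fold higher number from compound 1 to compound 3 (0.02 log units; within the scatter). The earlier step exchanged a single halogen, whereas these steps alter the arrangement of the halogens on the ring as well, and the three compounds still cannot be told apart in this assay. Nothing available explains why these changes leave the numbers so close.

From the compounds shown here alone, all three compounds carry two halogens on this outer ring, so it remains open whether a plain phenyl ring, or one bearing a methoxy group or a nitrile, would stay within the scatter. Nor do these compounds tell what a longer chain in the shared core would do to the number.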